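A Chlorine-Bearing Benzyl Swap Awaiting Measurement

This account rests on a few compounds, and the source may have more. Where it says the series, first, only, none or still open, it means among the compounds named here.

- Compound 1 `O=C1/C(=C/c2ccccc2F)CN(C(=S)SCc2cn(Cc3ccccc3Cl)nn2)C/C1=C\c1ccccc1F` gives 46300 nM
- Compound 2 `O=C1/C(=C/c2ccccc2F)CN(C(=S)SCc2cn(Cc3ccc(F)cc3)nn2)C/C1=C\c1ccccc1F` gives 35700 nM

In a functional assay on DU-145 cells (Homo sapiens) for cytotoxicity, read by MTT assay, with a stated time of 24 h (a higher number here means a weaker inhibitor, a lower number a stronger inhibitor), compound 2 has a single measured neighbour, compound 1, and the two values lie within the scatter of each other. Compound 3 `O=C1/C(=C/c2ccccc2F)CN(C(=S)SCc2cn(Cc3cccc(Cl)c3)nn2)C/C1=C\c1ccccc1F` has not yet been measured. It differs from compound 2 as follows: 3-chlorophenyl in place of 4-fluorophenyl on a saturated chain carbon bound to an aromatic nitrogen. In words, 3-chlorophenyl stands in place of 4-fluorophenyl on a saturated chain carbon bound to an aromatic nitrogen. Going by the values given here, one measured step bears on this change, since it falls at the same place: a 1.3-fold lower number from compound 1 to compound 2 (0.11 log units; within the scatter). Among the compounds with values here, with only that small step as a guide, no change beyond the scatter is expected. The expected step is a 1.1-fold higher number from compound 2 to compound 3 (0.05 log units; within the scatter). Compound 3 is estimated at 40000 nM, with an expected range from 22000 nM to 70000 nM.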

Compound 3, half-maximal inhibitory concentration: > 80000 nM
Compound 3: only a limit was reported; the forecaster's own chance of this, stated with the estimate: 5%; at least 2.0-fold (0.30 log units) between middle value and limit.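

In this assay, compound 3 gives only a limit of the assay and not a number: the limit of > 80000 nM in this assay, at which 1 of the 3 values shown sits. Even so, 3-chlorophenyl in place of 4-fluorophenyl gives an at least 2.2-fold higher number from compound 2 to compound 3 (0.35 log units; beyond the scatter), so this place on a saturated chain carbon bound to an aromatic nitrogen is not indifferent to the group it carries, which the step within the scatter between compound 1 and compound 2 had not shown. Set against 2-chlorophenyl, the same group gives an at least 1.7-fold higher number from compound 1 to compound 3 (0.23 log units; that floor lies within the scatter), so the data do not establish a difference between these two chlorophenyl groups.

From the compounds shown here alone, how far compound 3 lies past its limit remains unknown, as does whether the halogen or its place on the ring accounts for the step from compound 2. The compounds shown also leave open how this place would respond to a phenyl ring carrying an amine or a carboxylic acid, or to a longer chain before the ring.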